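A few compounds are considered here, and "the series" means these few. Any claim that something is new, unique, unknown or untested is made for them only; others in the source may bear on it.

Measured so far:
compound 1, `CC1(C)CC(=O)N(c2ccccc2C(=O)OCC2CCCN(CCCc3ccccc3)C2)C1=O`, in an in vitro functional assay on HEK ts201 cells for antagonist activity at Neuronal acetylcholine receptor; alpha4/beta2 (Homo sapiens), read by fluorescence and calcium flux (on this read-out higher numbers stand for weaker inhibition and lower numbers for stronger inhibition), gives 4900 nM
compound 2, `O=C(NCc1ccccc1)c1ccccc1-c1ccccc1`, in this assay gives 7500 nM

Compound 1 has the lower of the two numbers, yet compound 2 lies within the scatter of it, so nothing separates the two. Compound 3, `O=C(OCC1CCCN(CCCc2ccccc2)C1)c1ccccc1-n1cc(-c2ccccc2)nn1`, is compound 1 with 4-phenyl-1H-1,2,3-triazol-1-yl in place of 3,3-dimethyl-2,5-dioxopyrrolidin-1-yl on an aromatic carbon. For the measured compounds named here, no measured pair shows a change of this kind, so there is no step to lean on. The expected step of a 1.1-fold lower number from compound 1 to compound 3 (0.04 log units; within the scatter) is therefore none beyond the scatter, in either direction. Compound 3 is estimated at 4500 nM, within a range from 1200 nM to 18000 nM.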

Compound 3, half-maximal inhibitory concentration: 2820 nM
Estimate against measurement, compound 3: 1.6-fold (0.20 log units) above, within the range that was stated.
By their numbers in this assay, from the lowest: compounds 3, 1 and 2 (each within the scatter of the next, the first and the last beyond it).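

In this assay, 4-phenyl-1H-1,2,3-triazol-1-yl in place of 3,3-dimethyl-2,5-dioxopyrrolidin-1-yl on this aromatic carbon gives a 1.7-fold lower number from compound 1 to compound 3 (0.24 log units; within the scatter) and so does not separate the two compounds. At this place, then, two quite different groups, one with two aromatic rings and the other with one non-aromatic ring, give numbers that cannot be told apart. Nothing available accounts for this result.

Going by these compounds, whether an amine or a carboxylic acid on this carbon would move the number beyond the scatter remains open. So does what a plain 1H-1,2,3-triazol-1-yl, without its phenyl, would give.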